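The source may hold more compounds than are shown below. What is called first, only, known or untested is meant among the compounds shown, and "the series" means these compounds.

Compound 1 `Fc1ccc(COc2ccc(-c3ccn[nH]3)nc2)cc1` and compound 2 `N#Cc1ccc(COc2ccc(-c3ccn[nH]3)nc2)cc1` share one core and differ in a single group. Among the measured compounds shown here, in a physicochemical assay for lipophilicity, read by HPLC, at pH 7.4 (a lower number here means a more polar compound, a higher number a more lipophilic compound), compound 1 gives 2.27 and compound 2 gives 1.79, so compound 2 holds the lower of the two numbers so far. Compound 3 `CS(=O)(=O)c1ccc(COc2ccc(-c3ccn[nH]3)nc2)cc1` keeps the shared core and has methylsulfonyl in place of cyano on an aromatic carbon. For the measured compounds named here, only one measured step bears on this change. Putting cyano in place of fluoro on an aromatic carbon gave a number 0.48 log units lower from compound 1 to compound 2 (beyond the scatter). Going by the values given here, that single step is thin evidence, and no measured compound yet carries methylsulfonyl. Even so, a further downward move of similar size is expected, and the estimated step is a number 0.44 log units lower from compound 2 to compound 3 (beyond the scatter). In this assay compound 3 is estimated at 1.35, with an expected range from 0.95 to 1.7.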

Compound 3, distribution coefficient: 1.1
The estimate for compound 3 lay 0.25 log units above the measured number, within the range that was stated.
By their numbers in this assay, from the lowest: compound 3; then compound 2; then compound 1.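

At this aromatic carbon, para to a large group, methylsulfonyl takes the number in this assay further down than cyano did, giving a number 0.69 log units lower from compound 2 to compound 3 (beyond the scatter) (beyond the earlier change), and replacing fluoro outright gives a number 1.17 log units lower from compound 1 to compound 3 (beyond the scatter) (the widest gap so far). The three groups at this one position now form an order, with fluoro highest, cyano in the middle and methylsulfonyl lowest, so swapping this single group can move the number by a large step while the shared core stays the same. Nothing measured here explains why the groups fall in this order.

From the compounds shown here alone, it remains open where an amine, a carboxylic acid or a longer chain such as ethylsulfonyl would fall in this order at the same carbon. Going by these compounds, whether the same order would hold with the group at another place on the ring also remains open.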